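The source may report more compounds than this note shows. Statements on the series, on what has been measured and on what is new or still open speak of the compounds shown alone.

Compound 1 `NC(=O)CCn1ccc2c(Nc3ccc(OC(F)(F)F)cc3)ncnc21` and compound 2 `CCCn1ncc2c(Nc3ccc(OC(F)(F)F)cc3)ncnc21` share a core and differ in the group attached to it. In an ADME assay on BaF3 cells (Mus musculus) for cytotoxicity (on this read-out higher numbers stand for an effect only at larger amounts of compound and lower numbers for an effect already at smaller amounts), compound 1 reaches only the limit of the test, > 10000 nM, so no number is known for it. Compound 1 thus sits at the limit of > 10000 nM in this assay, at which 1 of the 2 values shown sits. In this assay, for the measured compounds named here, compound 2 gives 6600 nM, the only true number among the two values shown. Compound 3 `NC(=O)c1ccc(Cn2ncc3c(Nc4ccc(OC(F)(F)F)cc4)ncnc32)cc1` is not yet measured. It differs from compound 2 in one place: 4-carbamoylphenyl in place of ethyl on a saturated chain carbon bound to an aromatic nitrogen. Going by the values given here, no measured pair shows this kind of change, so the direction of the step from compound 2 to compound 3 cannot be read from a neighbour. The expectation is a modest step upward, a 1.4-fold higher number from compound 2 to compound 3 (0.13 log units; within the scatter), close to the usual scatter. Compound 3 is therefore expected at about 9000 nM, within a range from 3000 nM to 25000 nM, with a fair chance that only a limit is recorded.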

Compound 3, half-maximal effective concentration: > 10000 nM
Compound 3 was reported as a limit; the forecaster's own chance of this, stated with the estimate: 40%; middle value at least 1.1-fold (0.04 log units) away from the limit.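

Compound 3 gives only a limit in this assay, > 10000 nM. Going by these compounds, replacing ethyl with 4-carbamoylphenyl on a saturated chain carbon bound to an aromatic nitrogen gives an at least 1.5-fold higher number from compound 2 to compound 3 (0.18 log units; that floor lies within the scatter), the first step measured at this place, so a much bigger group with an aromatic ring brings no effect on the cells within the tested range, although the true size of the step remains unknown. The upper end of the test now caps most of the compounds shown, so further upward changes here could not be sized: the limit of > 10000 nM in this assay, at which 2 of the 3 values shown sit.

The compounds shown do not reveal whether the benzene ring or the carbamoyl group accounts for this step. A plain benzyl group or a butyl chain in place of propyl would help separate the two.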